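The compounds below may be only part of what the source reports. "The series", "measured", "known", "first", "only" and "open" are said of these compounds alone.

Measured so far in a physicochemical assay for solubility, in phosphate buffer, measured as kinetic solubility, with a stated time of 1 h, at pH 7.4; on this read-out higher numbers stand for higher solubility and lower numbers for lower solubility: compound 1 `COc1ccc2nc(C)cc(OCC(=O)Nc3cc(C)ccc3OC)c2c1` gives 9500 nM; compound 2 `COc1ccc2nc(C)cc(OCC(=O)Nc3ccc(Cl)cc3)c2c1` gives 9000 nM; compound 3 `COc1ccc2nc(C)cc(OCC(=O)Nc3cccnc3)c2c1` gives 32000 nM.

Compound 3 stands highest of the three: the steps of a 3.4-fold higher number from compound 1 to compound 3 (0.53 log units; beyond the scatter) and a 3.6-fold higher number from compound 2 to compound 3 (0.55 log units; beyond the scatter) are both beyond the scatter, while a 1.1-fold lower number from compound 1 to compound 2 (0.02 log units; within the scatter) is within it. Compound 4 `COc1ccc2nc(C)cc(OCC(=O)Nc3ccncc3)c2c1` carries pyridin-4-yl in place of pyridin-3-yl on an amide-type nitrogen; the two have the same atoms, joined differently. Among the measured compounds shown here, no measured step swaps one pyridinyl for another; the steps that touch the amide-type nitrogen all replace a substituted phenyl with pyridin-3-yl and were modest. For compound 4 in this assay the step of a 1.1-fold lower number from compound 3 to compound 4 (0.03 log units; within the scatter) is therefore expected to stay within the scatter. Compound 4 is estimated at 30000 nM, in the range 12000 nM to 75000 nM.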

Compound 4, solubility: 91500 nM
Compound 4: middle estimate off by 3.1-fold (0.48 log units), on the low side; measured number above the stated range.
By their numbers in this assay, from the lowest: compounds 2 and 1 (each within the scatter of the next); then compound 3; then compound 4.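

In this assay, moving between pyridin-3-yl and pyridin-4-yl on an amide-type nitrogen, with the same atoms joined differently, is a step of its own: a 2.9-fold higher number from compound 3 to compound 4 (0.46 log units; beyond the scatter) is beyond the scatter. Against the substituted phenyls the gap is wider, with a 10-fold higher number from compound 2 to compound 4 (1.01 log units; beyond the scatter) and a 9.6-fold higher number from compound 1 to compound 4 (0.98 log units; beyond the scatter) both beyond the scatter. Nothing at hand accounts for the difference between the two pyridinyl isomers.

Open, from the compounds shown here alone, is where pyridin-2-yl would fall relative to these two isomers. Also open, going by these compounds, is whether an amine or a methyl group on the pyridin-4-yl ring would keep the number seen for compound 4.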